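This account rests on a few compounds, and the source may have more. Where it says the series, first, only, none or still open, it means among the compounds named here.

Going by the values given here, in a functional assay on U-373MG ATCC cells (Homo sapiens) for inhibition, read by colorimetric assay and MTT assay, with a stated time of 72 h (a higher number here means a weaker inhibitor, a lower number a stronger inhibitor), compound 1 (`Cn1c2cnc1OCCCCCCCCCCCOc1ccccc1-2`) gives 48000 nM as the only number in this small set. Compound 2 (`CCCCCCOc1ncc(-c2ccccc2OC)n1C`) has no single number to stand on, since compound 2 is recorded as "not determined" (no result reported) in this series, and compound 3 (`COc1ccccc1-c1cnc(OCC(F)(F)C(F)(F)C(F)(F)C(F)(F)C(F)(F)F)n1C`) shares that position, being entered as "not determined" (no result reported) as well. The account now moves to compound 4 (`COc1ccccc1-c1cnc(OC)n1C`), which is related by the difference hydrogen in place of pentyl on a saturated chain carbon bound to an oxygen on an aromatic ring with hydrogen in place of pentyl on a saturated chain carbon bound to an oxygen on an aromatic ring, so that hexyloxy becomes methoxy. Among the compounds with values here, no measured step supports this change, and its size in this assay cannot be read from the data. Within the data shown here, the expectation is only that compound 4 remains a weak inhibitor, close to compound 1 at 48000 nM or perhaps somewhat weaker, with no gain beyond the scatter. For compound 4 the half-maximal inhibitory concentration is estimated at 70000 nM with 25000 nM to 200000 nM as its expected range.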

Compound 4, half-maximal inhibitory concentration: > 100000 nM
Compound 4: a limit, no number; the forecaster's own chance of this, stated with the estimate: 40%; at least 1.4-fold (0.15 log units) between middle value and limit.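

Compound 4 gives > 100000 nM in this assay, which is a limit and not a number. Going by these compounds alone, compound 2 has no single number, so no step from compound 2 to compound 4 can be read. The compounds shown leave open how hexyloxy and methoxy compare in this assay.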